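The compounds below may be only part of what the source reports. "The series", "measured", "known", "first", "only" and "open" are said of these compounds alone.

Measured in a functional assay on NCI-H292 cells (Homo sapiens) for cytotoxicity, read by MTT assay, with a stated time of 72 h, tested at 5 ug/mL; on this read-out higher numbers stand for more inhibition of growth at the one concentration tested and lower numbers for less inhibition of growth:
compound 1 `O=C1NC(=S)/C(=C/c2cccc(Cl)c2)S1` gives 21.6%
compound 2 `O=C1NC(=S)/C(=C/c2cccc(F)c2)S1` gives 13.1%

Compound 2 holds the lowest of the two numbers, with compound 1 as its nearest neighbour; the step of a number 8.5 percentage points lower from compound 1 to compound 2 (within the scatter) lies within the scatter. Compound 3 `O=C1NC(=S)/C(=C/c2cccc(Br)c2)S1` is not yet measured and differs from compound 2 by bromo in place of fluoro on an aromatic carbon. For the measured compounds named here, the one measured step that bears on this change, a number 8.5 percentage points lower from compound 1 to compound 2 (within the scatter), exchanged one halogen for another on the aromatic carbon and stayed within the scatter. No step beyond the scatter is therefore expected in this assay. For compound 3 the estimate is 20%, with a range from 8% to 32%, which means an expected step of a number 6.9 percentage points higher from compound 2 to compound 3 (within the scatter).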

Compound 3, percent growth inhibition at one concentration: 22%
For compound 3 the middle estimate is 2 percentage points below the measured one; measured number inside the range.
By their numbers in this assay, from the lowest: compounds 2, 1 and 3 (each within the scatter of the next).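

In this assay bromo in place of fluoro on the aromatic carbon gives a number 8.9 percentage points higher from compound 2 to compound 3 (within the scatter) and bromo in place of chloro gives a number 0.4 percentage points higher from compound 1 to compound 3 (within the scatter) so all three halogens at this position now lie within the scatter of one another. Fluoro, chloro and bromo on this carbon thus show no separable order on this read-out. Nothing at hand offers an explanation for these numbers.

From the compounds shown here alone, whether an amine, a carboxylic acid or a methoxy group on this carbon would give a step beyond the scatter remains open. So does the effect of moving a halogen to another carbon of the ring.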